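A few compounds are considered here, and "the series" means these few. Any claim that something is new, unique, unknown or untested is made for them only; others in the source may bear on it.

In a physicochemical assay for solubility, at pH 7 (a higher number here means a more soluble compound, a lower number a less soluble compound), two compounds that share one core have been measured so far: compound 1 `CN1CCC(C(=O)N2Cc3c(NC(=O)c4ccsc4)n[nH]c3C2(C)C)CC1` and compound 2 `CN1CCC(C(=O)N2Cc3c(NC(=O)c4ccc(F)c(F)c4)n[nH]c3C2(C)C)CC1`. Compound 1 gives > 225000 nM, which is a limit of the assay and not a number. Compound 2 gives > 225000 nM, which is also a limit and not a number. Compound 2 therefore stands at the limit of > 225000 nM in this assay, at which 2 of the 2 values shown sit, with no exact figure known for it.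

The next structure, compound 3 `CN1CCC(C(=O)N2Cc3c(NC(=O)Nc4cccc(F)c4)n[nH]c3C2(C)C)CC1`, keeps the core and changes one piece: (3-fluorophenyl)amino in place of 3,4-difluorophenyl on a carbonyl carbon. Put simply, (3-fluorophenyl)amino takes the place of 3,4-difluorophenyl on a carbonyl carbon.

Among the compounds with values here, only one measured step bears on this: a step that the two limits leave unreadable from compound 1 to compound 2. It also swaps the group on a carbonyl carbon, but both of its ends are limits, so it offers no size to carry over. It gives only weak support for expecting little change, and the new group differs in kind from those measured so far.

The expected change is an at least 1.1-fold lower number from compound 2 to compound 3 (0.05 log units; that floor lies within the scatter), and this estimate is a loose one. For compound 3, the estimated value is 200000 nM, with an expected range from 90000 nM to 300000 nM.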

Compound 3, solubility: > 225000 nM
Compound 3: only a limit was reported (the forecaster's own chance of this, stated with the estimate: 60%); middle value at least 1.1-fold (0.05 log units) from the limit.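

In this assay compound 3 gives > 225000 nM, which is a limit of the assay and not a number. No step among compound 1, compound 2 and compound 3 can therefore be read, and all three stand together: the limit of > 225000 nM in this assay, at which 3 of the 3 values shown sit.

The compounds shown leave open how far their true values lie apart, and so what changing the group on the carbonyl carbon does in this assay.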